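Chloro for hydroxy on a weakly active sulfonamide

This account rests on a few compounds, and the source may have more. Where it says the series, first, only, none or still open, it means among the compounds named here.

In a functional assay on DU-145 cells (Homo sapiens) for antiproliferative activity, read by MTT assay, with a stated time of 72 h (on this read-out lower numbers stand for stronger inhibition and higher numbers for weaker inhibition), compound 2 `CCN(c1ccc(O)cc1)S(=O)(=O)C1CC2OC1C(c1ccc(NC(=O)CCCCCCC(=O)O)cc1)=C2c1ccc(O)cc1` is reported only as a limit, > 100000 nM. Its close relative, compound 1 `CCN(c1cccc(OC)c1)S(=O)(=O)C1CC2OC1C(c1ccc(NC(=O)CCCCCCC(=O)O)cc1)=C2c1ccc(O)cc1`, gives a number, 71100 nM. Within the data shown here, the one measured step, an at least 1.4-fold higher number from compound 1 to compound 2 (0.14 log units; that floor lies within the scatter), concerns the same sulfonamide nitrogen and yields only a floor that lies within the scatter. Compound 3 `CCN(c1ccc(Cl)cc1)S(=O)(=O)C1CC2OC1C(c1ccc(NC(=O)CCCCCCC(=O)O)cc1)=C2c1ccc(O)cc1` differs from compound 2 in a single substituent chloro in place of hydroxy on an aromatic carbon, para to a large group. Among the measured compounds shown here, that single step gives no sign of a large effect at this aryl group, and compound 1 at 71100 nM is the only number nearby, so a modest shift towards lower numbers is expected in this assay. The expected change is small, an at least 1.6-fold lower number from compound 2 to compound 3 (0.22 log units; that floor lies within the scatter). For compound 3 the estimated value is 60000 nM, with an expected range of 20000 nM to 100000 nM.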

Compound 3, half-maximal inhibitory concentration: 42100 nM
Beside the measured number, compound 3's estimate is 1.4-fold (0.15 log units) above it, within the range that was stated.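

In this assay, the aryl group on the sulfonamide nitrogen now gives a step that clears the scatter, an at least 2.3-fold lower number from compound 2 to compound 3 (0.37 log units; beyond the scatter), so 4-chlorophenyl and 4-hydroxyphenyl can be told apart here, which the earlier floor at this nitrogen could not do. Going by these compounds, compound 2 is reported only as a limit, so this step is a floor and its full size stays unknown: the limit of > 100000 nM in this assay, at which 1 of the 3 values shown sits. The other step, a 1.7-fold lower number from compound 1 to compound 3 (0.23 log units; within the scatter), does not separate 4-chlorophenyl from 3-methoxyphenyl.

The compounds shown leave open whether fluoro or an amine in place of the hydroxy would also clear the scatter from compound 2. Also open, on these data alone, is what a longer chain in place of ethyl on the sulfonamide nitrogen, or a hydroxamic acid in place of the carboxylic acid, would do in this assay.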